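This account rests on a few compounds, and the source may have more. Where it says the series, first, only, none or still open, it means among the compounds named here.

Of the compounds shown here, three of one shared core have been measured in a functional assay on MDA-MB-231 cells (Homo sapiens) for inhibition, read by MTT assay, with a stated time of 24 h, tested at 100 uM; a lower number here means less inhibition, a higher number more inhibition at the concentration tested (going by the name of the read-out). Compound 1 `COc1ccc(/C=N/NC(=O)c2ccc(O[C@@H]3O[C@H](CO)[C@@H](O)[C@H](O)[C@H]3O)cc2)cc1` gives 11.3%, compound 2 `O=C(N/N=C/C1CCCCC1)c1ccc(O[C@@H]2O[C@H](CO)[C@@H](O)[C@H](O)[C@H]2O)cc1` gives 0.88%, and compound 3 `O=C(N/N=C/c1ccc([N+](=O)[O-])cc1)c1ccc(O[C@@H]2O[C@H](CO)[C@@H](O)[C@H](O)[C@H]2O)cc1` gives 7.12%. Compound 3 therefore sits second highest of the three; its nearest neighbour is compound 1, its furthest compound 2, yet a number 6.2 percentage points higher from compound 2 to compound 3 (within the scatter) and a number 4.2 percentage points lower from compound 1 to compound 3 (within the scatter) both fall within the scatter, so none of these can be ranked against compound 3. Only a number 10.4 percentage points lower from compound 1 to compound 2 (beyond the scatter) stands beyond the scatter.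

Compound 4 `O=C(N/N=C/c1ccccc1)c1ccc(O[C@@H]2O[C@H](CO)[C@@H](O)[C@H](O)[C@H]2O)cc1` differs from compound 3 in one place: hydrogen in place of nitro on an aromatic carbon. For the measured compounds named here, no measured step removes a group from this aromatic carbon entirely, so the closest guide is the exchange of one group for another at the same place, a number 4.2 percentage points lower from compound 1 to compound 3 (within the scatter), which was within the scatter. On that basis, a step no larger than the scatter is expected, a number 0.9 percentage points higher from compound 3 to compound 4 (within the scatter), and compound 4 is estimated at 8%, within a range from 0% to 20%.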

Compound 4, a percentage reported as inhibition, at one concentration (the size of the read-out at that concentration, not a potency): 3.56%
Compound 4: the middle estimate sits 4.4 percentage points above what was measured, within the range that was stated.
By their numbers in this assay, from the lowest: compounds 2, 4, 3 and 1 (each within the scatter of the next, the first and the last beyond it).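

In this assay, hydrogen in place of nitro gives a number 3.6 percentage points lower from compound 3 to compound 4 (within the scatter), and hydrogen in place of methoxy gives a number 7.7 percentage points lower from compound 1 to compound 4 (within the scatter), so with the bare phenyl now available as a reference, neither substituent on this aromatic carbon can be told apart from hydrogen. Phenyl in place of cyclohexyl gives a number 2.7 percentage points higher from compound 2 to compound 4 (within the scatter), so compound 4 cannot be separated from any of the other three compounds, and the only step beyond the scatter remains a number 10.4 percentage points lower from compound 1 to compound 2 (beyond the scatter). No independent measurement is available to explain these numbers.

Still open, going by these compounds, is whether an amine or a carboxylic acid on this aromatic carbon would produce a step beyond the scatter. Also open, on these data alone, is whether a longer chain in place of the cyclohexyl would do so.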